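The compounds below may be only part of what the source reports. "The series", "measured", "known", "first", "only" and "open" are said of these compounds alone.

Three compounds share one core and differ only in the length of the saturated chain attached to the sulfur. Compound 1 `CCCCCSC[C@H](NC(C)=O)C(=O)CCl` carries a pentyl chain, compound 2 `CCCCCCSC[C@H](NC(C)=O)C(=O)CCl` a hexyl chain, and compound 3 `CCCCCCCCSC[C@H](NC(C)=O)C(=O)CCl` an octyl chain. In a functional assay on NALM-6 cells (Homo sapiens) (on this read-out higher numbers stand for weaker inhibition and lower numbers for stronger inhibition), compound 1 gives 5800 nM, compound 2 gives 3300 nM, and compound 3 gives 5600 nM. Compound 3 thus stands second highest of the three numbers, with compound 1 nearest and compound 2 furthest, yet every gap among them lies within the scatter: a 1.8-fold lower number from compound 1 to compound 2 (0.24 log units; within the scatter), a 1.0-fold lower number from compound 1 to compound 3 (0.02 log units; within the scatter), and a 1.7-fold higher number from compound 2 to compound 3 (0.23 log units; within the scatter).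

Compound 4 `CCCCCCCCCCCSC[C@H](NC(C)=O)C(=O)CCl` lengthens the chain once more; the change from compound 3 is propyl in place of hydrogen on a saturated chain carbon, eight bonds along the chain from a sulfur. All three measured steps are chain extensions of the same kind, and none of them shifted this assay beyond the scatter. Going by the values given here, no measured step reaches as far out along the chain as this one, so the expectation rests on those shorter extensions alone. On that basis no step beyond the scatter is expected, a 1.1-fold higher number from compound 3 to compound 4 (0.03 log units; within the scatter). Compound 4 is therefore estimated at 6000 nM, with a range from 2500 nM to 14000 nM.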

Compound 4, half-maximal inhibitory concentration: 1700 nM
For compound 4 the middle estimate is 3.5-fold (0.55 log units) above the measured one; the whole stated range lies above it.
By their numbers in this assay, from the lowest: compounds 4, 2, 3 and 1 (each within the scatter of the next, the first and the last beyond it).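

Among all the chain extensions in this series, the only steps that pass beyond the scatter in this assay end at compound 4, with its propyl added eight bonds along the chain from the sulfur: there is a 3.3-fold lower number from compound 3 to compound 4 (0.52 log units; beyond the scatter) and there is a 3.4-fold lower number from compound 1 to compound 4 (0.53 log units; beyond the scatter), both modest in size. Extending the chain at this far position can therefore change the number, which the shorter chains did not show, as their values all stayed within the scatter of one another. This is still no steady trend, and compound 2 goes against any rule that a longer chain simply gives a lower number: there is a 1.9-fold lower number from compound 2 to compound 4 (0.29 log units; within the scatter), so compound 2 and compound 4 cannot be told apart, while compound 3, with a chain of intermediate length, sits apart from compound 4. Nothing available here bears on the reason for this result.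

Going by these compounds, whether a still longer chain would keep the number this low or raise it again remains open. So does whether a chain carrying an amine or a carboxylic acid would fit the same picture in this assay.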